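The source may report more compounds than this note shows. Statements on the series, on what has been measured and on what is new or still open speak of the compounds shown alone.

Compound 1 `CC1=CC[C@H](C(C)(C)NC(=S)N/N=C/c2ccc(O)cc2)CC1` was examined in a functional assay on UACC-62 cells (Homo sapiens) for inhibition, read by sulforhodamine B assay, with a stated time of 48 h; a lower number here means a stronger inhibitor of growth, a higher number a weaker inhibitor of growth. In this assay compound 1 gives only a limit, > 100000 nM, so no number is known for it. Compound 2 `CC1=CC[C@H](C(C)(C)NC(=S)N/N=C/c2ccc(N(C)C)cc2)CC1` carries dimethylamino in place of hydroxy on an aromatic carbon. In this assay compound 2 likewise gives only a limit, > 100000 nM. The step that the two limits leave unreadable from compound 1 to compound 2 cannot be read, because of the limit of > 100000 nM in this assay, at which 2 of the 2 values shown sit. The change to compound 3 `CC1=CC[C@H](C(C)(C)NC(=S)N/N=C/c2cccs2)CC1` is thiophen-2-yl in place of 4-hydroxyphenyl on a carbon with a double bond to nitrogen. Within the data shown here, no measured step bears directly on this change, and the one step available is unreadable, so the expectation rests on both measured compounds sitting at the limit. The step that the limit leaves unreadable from compound 1 to compound 3 is expected to be small or none beyond the scatter. Compound 3 is therefore estimated at 150000 nM, with a range from 40000 nM to 600000 nM, and most probably it will again be reported only as a limit.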

Compound 3, concentration for total growth inhibition: 19000 nM
Beside the measured number, compound 3's estimate is 7.9-fold (0.90 log units) above it; measured number below the stated range.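

Compound 3 is the only one of the three compounds shown with a true number in this assay, so what stands at this place can move the read-out out of the range where only a limit is seen. Thiophen-2-yl in place of 4-hydroxyphenyl gives an at least 5.2-fold lower number from compound 1 to compound 3 (0.72 log units; beyond the scatter). That step is only a minimum and the step between compound 1 and compound 2 cannot be read, because both of those compounds stop at a limit: the limit of > 100000 nM in this assay, at which 2 of the 3 values shown sit.

Which feature of the new ring matters stays open, as ring size, the sulfur atom and the absence of the hydroxy group all change together in this one step. A furan-2-yl or an unsubstituted phenyl group at this place would help to tell these apart.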